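The source may hold more compounds than are shown below. What is called first, only, known or untested is meant among the compounds shown, and "the series" means these compounds.

Measured compounds:
compound 1 `NC(=O)c1c(NC(=O)c2ccccc2Cl)sc2c1CCN(Cc1ccccc1)C2`, 14500 nM in a functional assay on MKN-74 cells (Homo sapiens) for antiproliferative activity, with a stated time of 24 h; on this read-out lower numbers stand for stronger inhibition and higher numbers for weaker inhibition
compound 2 `NC(=O)c1c(NC(=O)c2ccccc2Cl)sc2c1CCN(C(=S)Nc1ccccc1)C2`, 15600 nM in this assay

Compound 2 stands at the higher of the two numbers, but the step of a 1.1-fold higher number from compound 1 to compound 2 (0.03 log units; within the scatter) lies within the scatter, so the two compounds cannot be ordered. Compound 3 `NC(=O)c1c(NC(=O)c2ccccc2Cl)sc2c1CCN(C(=O)Nc1ccccc1Cl)C2` differs from compound 2 by a group of 10 heavy atoms (7 carbon, 1 nitrogen, 1 oxygen, 1 chlorine; one six-membered aromatic ring of carbon only) in place of a group of 9 heavy atoms (7 carbon, 1 nitrogen, 1 sulfur; one six-membered aromatic ring of carbon only), on an amine nitrogen in a ring. Within the data shown here, the only measured step, from compound 1 to compound 2, changed the same ring nitrogen and stayed within the scatter; no step tests the exchange of the thiocarbonyl for a carbonyl or the added chlorine. No step beyond the scatter is therefore expected in this assay, and compound 3 is estimated at 15000 nM (range 5000 nM to 45000 nM), a step of a 1.0-fold lower number from compound 2 to compound 3 (0.02 log units; within the scatter).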

Compound 3, half-maximal inhibitory concentration: 16300 nM
Compound 3: middle estimate off by 1.1-fold (0.04 log units), on the low side, within the range that was stated.
By their numbers in this assay, from the lowest: compounds 1, 2 and 3 (each within the scatter of the next).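

Putting (2-chlorophenyl)carbamoyl on the amine nitrogen in a ring gave a 1.0-fold higher number from compound 2 to compound 3 (0.02 log units; within the scatter) in this assay, and the comparison with benzyl gave a 1.1-fold higher number from compound 1 to compound 3 (0.05 log units; within the scatter). All three groups on this nitrogen, now including one with a carbonyl and a chlorine, therefore cannot be ordered. Nothing measured here offers an explanation for this. From the compounds shown here alone, the carbonyl and the chlorine arrive together, so their separate contributions stay open. Going by these compounds, whether an acetyl group or a carboxylic acid on this nitrogen, or a change in the shared core, would produce a step beyond the scatter also remains open.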